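Sulfamoyl in Place of Methoxy on a Triazole-Linked Phenyl Ring

A few compounds are considered here, and "the series" means these few. Any claim that something is new, unique, unknown or untested is made for them only; others in the source may bear on it.

Compound 1 `N#CC1=C(N)Oc2c(c3nc4ccccc4nc3c3ccccc23)C12C(=O)N(Cc1cnnn1-c1ccc(F)cc1)c1ccccc12` gives in an ADME assay on HUVEC cells (Homo sapiens) for antiproliferative activity, read by MTT assay, with a stated time of 48 h (a lower number here means a stronger inhibitor, a higher number a weaker inhibitor), a value of > 50000 nM, which is a limit of the assay and not a number.
Compound 2 `N#CC1=C(N)Oc2c(c3nc4ccccc4nc3c3ccccc23)C12C(=O)N(Cc1cnnn1-c1cccc(Cl)c1)c1ccccc12` gives in this assay a value of > 50000 nM, again a limit of the assay.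
Compound 3 `COc1ccc(-n2nncc2CN2C(=O)C3(C(C#N)=C(N)Oc4c3c3nc5ccccc5nc3c3ccccc43)c3ccccc32)cc1` gives in this assay a value of > 50000 nM, likewise a limit of the assay.

Compound 3 therefore stands at the limit of > 50000 nM in this assay, at which 3 of the 3 values shown sit, and no number separates it from the other two. The steps between the measured compounds, a step that the two limits leave unreadable from compound 1 to compound 2, a step that the two limits leave unreadable from compound 1 to compound 3 and a step that the two limits leave unreadable from compound 2 to compound 3, are all of a size that the two limits leave unreadable, so none of them tells how a change on this phenyl ring moves the read-out.

Compound 4 `N#CC1=C(N)Oc2c(c3nc4ccccc4nc3c3ccccc23)C12C(=O)N(Cc1cnnn1-c1ccc(S(N)(=O)=O)cc1)c1ccccc12` differs from compound 3 in one place: sulfamoyl in place of methoxy on an aromatic carbon. Going by the values given here, no measured step bears on this change with a readable size; the only guidance is that every change on this ring so far has left the value at the limit. Compound 4 is therefore expected to remain near that limit, at an estimated 60000 nM, with an expected range from 20000 nM to 200000 nM. The expected step is a step that the limit leaves unreadable from compound 3 to compound 4, estimated as none beyond the scatter.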

Compound 4, half-maximal inhibitory concentration: > 50000 nM
Compound 4 ended at the assay's limit; the forecaster's own chance of this, stated with the estimate: 85%; the middle value is on the limit's open side.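

Compound 4 gives > 50000 nM in this assay, which is a limit of the assay and not a number, so the steps to compound 4 from compound 1, compound 2 and compound 3 cannot be read. The compounds shown leave open whether any change on this phenyl ring moves the read-out at all: the limit of > 50000 nM in this assay, at which 4 of the 4 values shown sit.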